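The compounds below may be only part of what the source reports. "The series", "measured", "known", "first", "only" and "open" are said of these compounds alone.

Within the data shown here, in a functional assay on COLO 205 cells (Homo sapiens) for inhibition, read by sulforhodamine B assay (on this read-out higher numbers stand for weaker inhibition of growth and lower numbers for stronger inhibition of growth), compound 1 (`Clc1cccc(-c2ccc(-c3ccc(-c4nc5ccccc5[nH]4)cc3)cc2)c1`) gives 100000 nM, the higher of the two numbers so far, and compound 2 (`COc1ccc(-c2ccc(-c3ccc(-c4nc5ccccc5[nH]4)cc3)cc2)cc1OC`) gives 41200 nM. Compound 3 (`Oc1cccc2[nH]c(-c3ccc(-c4ccc(-c5cccc(Cl)c5)cc4)cc3)nc12`) differs from compound 1 by one change: hydroxy in place of hydrogen on an aromatic carbon. Among the measured compounds shown here, the only measured step, a 2.4-fold lower number from compound 1 to compound 2 (0.39 log units; beyond the scatter), is modest and involves a different change, 3,4-dimethoxyphenyl in place of 3-chlorophenyl, so it offers only a rough guide to size. A similarly modest move to a lower number is therefore expected, namely a 2.9-fold lower number from compound 1 to compound 3 (0.46 log units; beyond the scatter). For compound 3 the estimated value is 35000 nM, with an expected range from 7000 nM to 100000 nM.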

Compound 3, concentration for 50% growth inhibition: 8600 nM
Compound 3: middle estimate off by 4.1-fold (0.61 log units), on the high side; low and high end bracket the measured number.
By their numbers in this assay, from the lowest: compound 3; then compound 2; then compound 1.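

In this assay, one hydroxy in place of hydrogen on an aromatic carbon of the six-membered carbon ring gives a 12-fold lower number from compound 1 to compound 3 (1.07 log units; beyond the scatter) and this step is large. Among these compounds, the earlier compounds left this part of the molecule unchanged, so this is the first sign that it can strongly shift growth inhibition, with only one heavy atom added. No available evidence explains the shift.

Still open, on these data alone, is whether hydroxy is special here, or whether an amine or a fluorine on the same carbon would do the same. Whether hydroxy on the ring's other carbons would match this step is also unknown.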